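Succinimide amides in the maximal electroshock model

The source may report more compounds than this note shows. Statements on the series, on what has been measured and on what is new or still open speak of the compounds shown alone.

Working notes on a small set of succinimide-bearing amides. Compound 1 `CC(C(=O)N1CCN(c2ccccc2C(F)(F)F)CC1)N1C(=O)CCC1=O` is the reference: in a functional assay on the whole organism (strain Swiss) with Mus musculus as the target, in the maximal electroshock model, with a stated time of 0.25 h, at a dose of 300 mg/kg by the intraperitoneal route (a higher number here means a stronger effect of the compound at the dose given, a lower number a weaker effect), compound 1 gives 100%. Compound 2 `CCC(C(=O)N1CCN(c2ccccc2C(F)(F)F)CC1)N1C(=O)CCC1=O` differs from it by methyl in place of hydrogen on a saturated chain carbon, two bonds along the chain from an amide-type nitrogen in a ring and a carbonyl carbon, and in this assay compound 2 gives 25%. That change produced a number 75 percentage points lower from compound 1 to compound 2 (beyond the scatter).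

Compound 3 `CC(C(=O)N1CCOCC1)N1C(=O)CCC1=O` carries a different core; the difference between the core of compound 1 and the core of compound 3 is not broken down here. In this assay compound 3 gives 0%, the lowest value of the three, its steps to compound 2 and to compound 1 both lying beyond the scatter.

Compound 4 `CCC(C(=O)N1CCOCC1)N1C(=O)CCC1=O` is not yet measured. It differs from compound 3 by methyl in place of hydrogen on a saturated chain carbon, two bonds along the chain from an amide-type nitrogen in a ring and a carbonyl carbon, the same change as that from compound 1 to compound 2, at the same place. In the measured pair the change cut the read-out sharply, but compound 3 leaves no room for a fall because compound 3 already stands at 0%. Compound 4 is therefore expected to remain near the floor, at about 0%. The expected step is no change at the digits printed from compound 3 to compound 4 (within the scatter), with the range 0% to 10% allowing only for ordinary scatter.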

Compound 4, a percentage reported as activity, at one dose (the size of the read-out at that dose, not a potency): 0%
Beside the measured number, compound 4's estimate shows no gap at the digits printed, within the range that was stated.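

In this assay, methyl in place of hydrogen on the saturated chain carbon gives no change at the digits printed from compound 3 to compound 4 (within the scatter), and the size of the step on the core of compound 1 does not carry over to the core of compound 3: the same change on two cores in this assay, a number 75 percentage points lower (beyond the scatter) from compound 1 to compound 2 and no change at the digits printed (within the scatter) from compound 3 to compound 4, 75 percentage points apart, beyond the scatter of two such steps. This does not show that the change is tolerated on the second core: compound 3 gives 0%, which leaves no room for a fall to appear. The difference between the two steps therefore rests on one side on a read-out that could not drop further, and one pair on each core sets no rule for how this change transfers across the series.

As far as these compounds go, it remains open how a longer chain such as propyl, an amine or a carboxylic acid at the same saturated chain carbon would read on the core of compound 1. From the compounds shown here alone, it also remains open whether compound 3 and compound 4 would separate at another dose or time.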